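Swapping the Tail on the Same Core

A few compounds are considered here, and "the series" means these few. Any claim that something is new, unique, unknown or untested is made for them only; others in the source may bear on it.

Measured compounds:
compound 1 `COc1cc2c(Oc3c(F)cc(NC(=O)NN4C(=O)CSC4c4c(F)cccc4F)cc3F)ccnc2cc1OCCCN1CCCC1`: 8350 nM
compound 2 `COc1cc2c(Oc3c(F)cc(NC(=O)NN4C(=O)C(C)SC4c4c(F)cccc4F)cc3F)ccnc2cc1OCCCN1CCCC1`: "not determined" (no result reported)

Among the measured compounds shown here, in a functional assay on MDA-MB-231 cells (Homo sapiens) for antiproliferative activity, read by MTT assay, with a stated time of 72 h (on this read-out higher numbers stand for weaker inhibition and lower numbers for stronger inhibition), compound 1 gives 8350 nM, the only number available here; compound 2 carries "not determined" (no result reported). Compound 3 `CCN1CCN(CCCOc2cc3nccc(Oc4c(F)cc(NC(=O)NN5C(=O)CSC5c5c(F)cccc5F)cc4F)c3cc2OC)CC1` differs from compound 1 by 4-ethylpiperazin-1-yl in place of pyrrolidin-1-yl on a saturated chain carbon, three bonds along the chain from an oxygen on an aromatic ring. For the measured compounds named here, no pair of measured compounds shows what this change does, so nothing anchors a direction. The step of a 1.0-fold lower number from compound 1 to compound 3 (0.02 log units; within the scatter) is expected to be small, not beyond the usual scatter. Compound 3 is therefore estimated at 8000 nM, with a range from 3000 nM to 22000 nM.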

Compound 3, half-maximal inhibitory concentration: 3100 nM
Estimate against measurement, compound 3: 2.6-fold (0.41 log units) above; the range from low to high includes it.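

In this assay, placing 4-ethylpiperazin-1-yl instead of pyrrolidin-1-yl at the end of the chain gives a 2.7-fold lower number from compound 1 to compound 3 (0.43 log units; beyond the scatter), the first sign that this position responds to the group it carries. The step is modest, but it shows that the larger ring is accepted here without any loss of activity. Nothing available gives a reason for the step.

Whether the second ring nitrogen or the ethyl group accounts for it stays open. So does how a morpholin-4-yl or 4-methylpiperazin-1-yl group, or a shorter chain, would compare.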